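Swapping an Ethyl Carbamate for a Benzyl Carbamate

The source may hold more compounds than are shown below. What is called first, only, known or untested is meant among the compounds shown, and "the series" means these compounds.

Measured compounds:
- compound 1 `COc1cc(C2CC(c3ccccc3)=NN2C(=O)OCc2ccccc2)cc(OC)c1OC`: > 10000 nM
- compound 2 `CCOC(=O)N1N=C(c2cccc(OC)c2)CC1c1cc(OC)c(OC)c(OC)c1`: 4110 nM

Both compounds were tested in a functional assay on HeLa cells (Homo sapiens) for antiproliferative activity, read by MTT assay, with a stated time of 48 h; a lower number here means a stronger inhibitor of growth, a higher number a weaker inhibitor of growth. For compound 1 the result of > 10000 nM is a limit of the assay and not a number. Within the data shown here, compound 2, at 4110 nM, therefore holds the only true number so far.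

Compound 3 `COc1cccc(C2=NN(C(=O)OCc3ccccc3)C(c3cc(OC)c(OC)c(OC)c3)C2)c1` has not yet been measured. It keeps the structure of compound 2 except at one place: phenyl in place of methyl on a saturated chain carbon bound to an oxygen next to a carbonyl group. This puts phenyl in place of methyl on a saturated chain carbon bound to an oxygen next to a carbonyl group, so ethoxycarbonyl becomes benzyloxycarbonyl. Among the measured compounds shown here, no measured pair isolates this change, so the expectation rests on little. Compound 1 also carries benzyloxycarbonyl, and its reading of > 10000 nM gives no number to work from. A small move toward weaker growth inhibition in this assay is expected, not clearly beyond the scatter. The estimated change is a 1.7-fold higher number from compound 2 to compound 3 (0.23 log units; within the scatter). For compound 3 the expected value is 7000 nM, within an estimated range of 2000 nM to 20000 nM.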

Compound 3, concentration for 50% growth inhibition: > 10000 nM
Compound 3: no number, only a limit (the forecaster's own chance of this, stated with the estimate: 40%); at least 1.4-fold (0.15 log units) between middle value and limit.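

Among these compounds, with compound 3, benzyloxycarbonyl can for the first time be set against ethoxycarbonyl on an otherwise unchanged structure, and in this assay phenyl in place of methyl on a saturated chain carbon bound to an oxygen next to a carbonyl group gives an at least 2.4-fold higher number from compound 2 to compound 3 (0.38 log units; beyond the scatter). This shows that growth inhibition at this position does not survive the change intact, something compound 1 alone could not show, as it differs from compound 2 in more than one place. The step has only a lower bound, and the step from compound 1 to compound 3 cannot be read, so methoxy in place of hydrogen on an aromatic carbon stays without a size here, because both compounds rest on the same assay limit: the limit of > 10000 nM in this assay, at which 2 of the 3 values shown sit.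

On these data alone, how far compound 3 lies past its limit remains unknown. Also open, as far as these compounds go, is whether a longer chain or an amine in place of phenyl at this carbon would keep growth inhibition closer to that of compound 2.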